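The compounds below may be only part of what the source reports. "The series", "measured", "known", "first", "only" and "open" are said of these compounds alone.

Measured in a functional assay on A549 cells (Homo sapiens) for inhibition, read by MTT assay, with a stated time of 48 h; a lower number here means a stronger inhibitor, a higher number a weaker inhibitor:
Compound 1 `COc1ccc2c(=O)c(/C=C/C(=O)Nc3cccc(Cl)c3)coc2c1`: 470 nM
Compound 2 `COc1ccc2c(=O)c(/C=C/C(=O)NCc3ccc(F)cc3)coc2c1`: > 100000 nM

The value for compound 2 is a limit of this assay and not a number. Compound 2 therefore stands at the limit of > 100000 nM in this assay, at which 1 of the 2 values shown sits, with no exact figure to start from.

Compound 3 `COc1ccc2c(=O)c(/C=C/C(=O)NCc3ccc(C)cc3)coc2c1` differs from compound 2 in one small place: methyl in place of fluoro on an aromatic carbon. Methyl takes the place of fluoro on an aromatic carbon, para to a large group, turning 4-fluorobenzyl into 4-methylbenzyl.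

Within the data shown here, only one measured step bears on this, and only indirectly. It is an at least 210-fold higher number from compound 1 to compound 2 (2.32 log units; beyond the scatter), a large loss that came with 4-fluorobenzyl in place of 3-chlorophenyl on the amide nitrogen. That step says nothing directly about swapping fluoro for methyl, but compound 3 keeps the benzyl type of group that compound 2 carries. So no step beyond the scatter is expected, and compound 3 may well end at the limit too.

The expected change is an at least 1.4-fold lower number from compound 2 to compound 3 (0.15 log units; that floor lies within the scatter). For compound 3 the estimate is 70000 nM, with an expected range of 10000 nM to 150000 nM.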

Compound 3, half-maximal inhibitory concentration: > 100000 nM
Compound 3 ended at the assay's limit (the forecaster's own chance of this, stated with the estimate: 60%); middle value at least 1.4-fold (0.15 log units) away from the limit.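

In this assay compound 3 gives > 100000 nM, which is a limit of the assay and not a number. Replacing 3-chlorophenyl with 4-methylbenzyl on the amide nitrogen gives an at least 210-fold higher number from compound 1 to compound 3 (2.32 log units; beyond the scatter), so the large loss is now seen with two different benzyl groups, not only with 4-fluorobenzyl. The step between the two benzyl compounds cannot be read, so the data do not tell how fluoro and methyl compare at this place on the ring, only that neither brings a measurable value back within the range of this test: the limit of > 100000 nM in this assay, at which 2 of the 3 values shown sit.

The compounds shown leave open whether another group at this place on the benzyl ring, such as methoxy or an amine, would bring back a measurable value. They also leave open how much of the loss goes with the benzyl type of group and how much with the missing 3-chloro group, a question that a 3-chlorobenzyl amide or a 4-methylphenyl amide on the same core could help to separate.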